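A Methyl Extension on a Weakly Active Sulfanyl Analogue

The compounds below may be only part of what the source reports. "The series", "measured", "known", "first", "only" and "open" are said of these compounds alone.

Three compounds built on a shared core were tested in a functional assay on the whole organism (strain Sprague-Dawley) for inhibition, with Rattus norvegicus as the target, with a stated time of 10 min; a lower number here means that less compound is needed, a higher number that more compound is needed for the effect. Compound 1, `CCCOc1ccccc1-c1ncc(C(=O)O)c(=O)[nH]1`, gives 0.9 mg/kg in this assay. Compound 2, `CC(C)COc1ccccc1-c1ncc(C(=O)O)c(=O)[nH]1`, gives 0.5 mg/kg in this assay. The two differ by methyl in place of hydrogen on a saturated chain carbon bound to two saturated chain carbons, and the step is a 1.8-fold lower number from compound 1 to compound 2 (0.26 log units; within the scatter).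

Compound 3, `CSc1ccccc1-c1ncc(C(=O)O)c(=O)[nH]1`, differs from compound 1 by methylsulfanyl in place of propoxy on an aromatic carbon. The value of compound 3 in this assay, > 20 mg/kg, is a limit of the assay and not a number. The step is an at least 22-fold higher number from compound 1 to compound 3 (1.34 log units; beyond the scatter), and from compound 2 it is an at least 40-fold higher number from compound 2 to compound 3 (1.60 log units; beyond the scatter).

Compound 4, `CCSc1ccccc1-c1ncc(C(=O)O)c(=O)[nH]1`, has not been measured in this assay. It differs from compound 3 by methyl in place of hydrogen on a saturated chain carbon bound to a sulfur. Going by the values given here, this is the same kind of change as the one from compound 1 to compound 2, but not the same: there the methyl enters on a saturated chain carbon bound to two saturated chain carbons, here on a saturated chain carbon bound to a sulfur. Since the earlier step was a 1.8-fold lower number from compound 1 to compound 2 (0.26 log units; within the scatter), the expectation for the change from compound 3 to compound 4 is a step of about a number no higher from compound 3 to compound 4 (the limit leaves the size open), resting on compound 3 sitting at the limit of > 20 mg/kg in this assay, at which 1 of the 3 values shown sits, and on compound 2 showing 0.5 mg/kg only with the oxygen-bearing chain. Compound 4 is therefore estimated at 20 mg/kg, with a likely range from 7 mg/kg to 60 mg/kg, and a good chance that this assay again reports only a limit.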

Compound 4, dose for 50% inhibition: 25 mg/kg
Compound 4: middle estimate off by 1.3-fold (0.10 log units), on the low side; measured number inside the range.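

The step from compound 3 to compound 4 in this assay cannot be read, because compound 3 stands at a limit and not at a number: the limit of > 20 mg/kg in this assay, at which 1 of the 4 values shown sits.

The methyl step on the saturated chain carbon bound to a sulfur therefore cannot be set beside a 1.8-fold lower number from compound 1 to compound 2 (0.26 log units; within the scatter), and the data neither show nor exclude that the change carries over from the oxygen-bearing chain to the sulfur-bearing one. What can be read is that compound 4, with its ethylsulfanyl group, stays far from both compounds with an oxygen-bearing chain, with a 50-fold higher number from compound 2 to compound 4 (1.70 log units; beyond the scatter) and a 28-fold higher number from compound 1 to compound 4 (1.44 log units; beyond the scatter).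

The compounds shown leave open how a propylsulfanyl or an isobutylsulfanyl group would read, since either would set sulfur against oxygen with the chain itself unchanged, which neither of these large steps does. They also leave open whether a methoxy or an ethoxy group would give numbers close to those of compound 1 and compound 2, or whether the short chain of compound 3 and compound 4 has a share in these steps.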